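The source may report more compounds than this note shows. Statements on the series, on what has been measured and on what is new or still open speak of the compounds shown alone.

Series notes. The set comprises compound 1 `COc1ccc(N(C)c2nc(C)nc3ccccc23)cc1C(=O)OCCC[Se]C#N`, compound 2 `COc1ccc(N(C)c2nc(C)nc3ccccc23)cc1C(=O)OCCCCC[Se]C#N`, compound 3 `CN(c1ccc([Se]C#N)cc1)c1nc(C2CC2)nc2ccccc12` and the still unmeasured compound 4 `COc1ccc(N(C)c2nc(C)nc3ccccc23)cc1OCCCCCC[Se]C#N`. Going by the values given here, in a functional assay on RKO cells (Homo sapiens) for inhibition, read by MTT assay, with a stated time of 48 h (on this read-out lower numbers stand for stronger inhibition and higher numbers for weaker inhibition), compound 1 gives 1140 nM, the highest of the three numbers so far; in this assay compound 2 gives 356 nM and compound 3 gives 51 nM.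

Compound 4 differs from compound 1 on an aromatic carbon of the shared core: a group of 10 heavy atoms (7 carbon, 1 nitrogen, 1 oxygen, 1 selenium; no ring) in place of a group of 9 heavy atoms (5 carbon, 1 nitrogen, 2 oxygen, 1 selenium; no ring), on an aromatic carbon. Among the compounds with values here, the only measured step with a direct bearing is a 3.2-fold lower number from compound 1 to compound 2 (0.51 log units; beyond the scatter), where the longer chain bearing the selenium group went with the lower number. Within the data shown here, compound 4 again carries a longer chain, but it also exchanges the ester-linked chain for an ether-linked one, and no measured pair isolates that exchange. Compound 3, built on a differently substituted core, stands far below compound 1 yet does not share the change in question, so it cannot calibrate it.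

On these data alone, on this basis a modest move downward in this assay is expected for compound 4, of the order seen from compound 1 to compound 2, with a wide margin because the linker exchange is untested. Compound 4 is expected to give about 400 nM in this assay, between 120 nM and 1300 nM, corresponding to an expected step of a 2.9-fold lower number from compound 1 to compound 4 (0.45 log units; beyond the scatter).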

Compound 4, half-maximal inhibitory concentration: 1540 nM
For compound 4 the middle estimate is 3.9-fold (0.59 log units) below the measured one; the whole stated range lies below it.
By their numbers in this assay, from the lowest: compound 3; then compound 2; then compounds 1 and 4 (each within the scatter of the next).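

In this assay, replacing the ester-linked chain on this aromatic carbon, ortho to a methoxy group, with the longer ether-linked chain gives a 1.4-fold higher number from compound 1 to compound 4 (0.13 log units; within the scatter), so this change leaves no readable difference between the two compounds. The earlier step, a 3.2-fold lower number from compound 1 to compound 2 (0.51 log units; beyond the scatter), came from a longer chain with the ester link kept, and compound 4 goes against any reading that a longer chain bearing the selenium group by itself brings a lower number in this series. Nothing available explains why the earlier step does not carry over to the ether-linked compound.

The compounds shown leave open how the link and the chain length each contribute, since no pair separates them; an ether-linked chain matching the length in compound 1 and an ester-linked chain matching the length in compound 4 would divide the change into single steps. Also open, on these data alone, is whether an amide link at this position would follow the ester-linked or the ether-linked compounds, and whether a still longer chain would change the picture for either link.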